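The compounds below may be only part of what the source reports. "The series", "measured", "known", "first", "only" and "open" are said of these compounds alone.

Of the compounds shown here, two carry a number so far in a functional assay on HL-60 cells (Homo sapiens) for cytotoxicity, read by CCK-8 assay, with a stated time of 72 h; a higher number here means a weaker inhibitor, a lower number a stronger inhibitor. Compound 1 `COc1ccccc1/C=c1\c(=O)[nH]/c(=C/c2cccc(Cl)c2Cl)c(=O)n1C` gives 200 nM, while compound 2 `C=CCn1c(=O)/c(=C\c2cc(F)ccc2C)[nH]c(=O)/c1=C\c1ccccc1OC` gives 2600 nM. Compound 1 therefore stands at the lower of the two values, and its gap to compound 2 lies beyond the scatter of repeated measurements. Compound 2 differs from compound 1 in more than one place, so the pair does not isolate any single structural change.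

Compound 3 `COc1ccccc1/C=c1/[nH]c(=O)/c(=C\c2ccccc2OC)n(C)c1=O` has not yet been measured in this assay. Its difference from compound 1 is this: 2-methoxyphenyl in place of 2,3-dichlorophenyl on a double-bonded chain carbon bound to an aromatic carbon. The group that enters is one compound 1 already carries. For the measured compounds named here, no pair of measured compounds shows this exchange on its own, so the size of the step is open. A modest loss is expected, a step of a 2.5-fold higher number from compound 1 to compound 3 (0.40 log units; beyond the scatter) that may yet fall within the scatter, because compound 1 at 200 nM is the only direct anchor. Compound 3 is estimated at 500 nM, within a range from 150 nM to 2000 nM.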

Compound 3, half-maximal inhibitory concentration: 16200 nM
Beside the measured number, compound 3's estimate is 32-fold (1.51 log units) below it; measured number outside the range, above it.
By their numbers in this assay, from the lowest: compound 1; then compound 2; then compound 3.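

In this assay, for the compounds shown here, the exchange of 2,3-dichlorophenyl for 2-methoxyphenyl on a double-bonded chain carbon bound to an aromatic carbon gives an 81-fold higher number from compound 1 to compound 3 (1.91 log units; beyond the scatter), and this is the only step so far that isolates a single structural change. It shows that this position is highly sensitive to the identity of its aromatic substituent, even though the two groups match in heavy-atom count and each holds one six-membered aromatic ring of carbon only; they differ in composition, with the entering group carrying one hydrogen-bond acceptor and the leaving group none. No measurement at hand accounts for the size of this loss.

This one step removes both chlorine atoms and brings in the methoxy group together, so the compounds shown cannot separate the contribution of either change. Also open, on these data alone, is how an unsubstituted phenyl, a 3-chlorophenyl or a phenyl ring carrying an amine would compare at this position, and whether the step would keep its size with other groups elsewhere on the core of compound 1.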